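The source may hold more compounds than are shown below. What is called first, only, known or untested is meant among the compounds shown, and "the series" means these compounds.

Working notes on the series. Compound 1 `Nc1ncnc2c1c(Oc1cccc(Cl)c1)nn2CC1CCNCC1` and compound 2 `Nc1ncnc2c1c(Oc1cccc(Cl)c1)nn2CC1CCOCC1` share one core and differ only in the group on the saturated chain carbon bound to an aromatic nitrogen. In an ADME assay on microsomes from liver (Rattus norvegicus) for metabolic stability, read by LC-MS, tested at 1 uM (a higher number here means that the compound lasts longer, a lower number that the compound disappears faster), compound 1 reaches > 1 h, which is a limit of the assay and not a number (the limit of > 1 h in this assay, at which 1 of the 2 values shown sits). In this assay compound 2 gives 0.233 h. Among the compounds with values here, the step of an at least 4.2-fold lower number from compound 1 to compound 2 (0.63 log units; beyond the scatter) is the only measured change so far.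

Compound 3 `Cc1cccc(Sc2nn(CC3CCNCC3)c3ncnc(N)c23)c1` keeps the (piperidin-4-yl)methyl group of compound 1 and changes the aromatic carbon instead: (3-methylphenyl)sulfanyl in place of 3-chlorophenoxy on an aromatic carbon. Within the data shown here, no measured step touches this position, so the step from compound 1 to compound 2 gives no direct guide for compound 3, and compound 1 itself stands only at a limit. The change from compound 1 to compound 3 is estimated as an at least 1.4-fold lower number from compound 1 to compound 3 (0.15 log units; that floor lies within the scatter). Compound 3 is therefore expected at 0.7 h, with a range from 0.3 h to 1.5 h.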

Compound 3, half-life: 0.433 h
Estimate against measurement, compound 3: 1.6-fold (0.21 log units) above, and the stated range covers the measured number.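

The aromatic carbon of the five-membered ring now has a measured step of its own in this assay: (3-methylphenyl)sulfanyl in place of 3-chlorophenoxy gives an at least 2.3-fold lower number from compound 1 to compound 3 (0.36 log units; beyond the scatter). This shows that the group at this position matters to the half-life with the (piperidin-4-yl)methyl group held constant, but the swap changes the linking atom and the ring substituent together, so the step belongs to the pair and not to either change alone. Compound 1 stands at a limit and not a number, so the step has only a floor: the limit of > 1 h in this assay, at which 1 of the 3 values shown sits.

A 3-methylphenoxy group at this carbon would separate the two changes. Also open, as far as these compounds go, is whether the step carries over when the oxan-4-yl group of compound 2 replaces piperidin-4-yl.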